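This account rests on a few compounds, and the source may have more. Where it says the series, first, only, none or still open, it means among the compounds named here.

Measured so far in an ADME assay on H9c2 cells (Rattus norvegicus) for cytotoxicity, read by MTT assay, with a stated time of 48 h; a lower number here means a stronger inhibitor, a higher number a weaker inhibitor:

compound 1 `CC(C)(Oc1ccc(Cl)cc1)C(=O)NCCOC(=S)Nc1ccc([N+](=O)[O-])cc1Cl`, > 800000 nM
compound 2 `O=C(NCCOC(=S)Nc1ccccc1)c1cccnc1`, > 800000 nM
compound 3 `O=C(CCCCC1CCSS1)OCCCOC(=O)c1cccnc1`, > 800000 nM

Each of these three readings is a limit of the assay and not a number; this is the limit of > 800000 nM in this assay, at which 3 of the 3 values shown sit. Compound 3 therefore stands at the limit, and nothing in the numbers shown separates it from compound 1 or compound 2: no order among the three can be read from the values, only that none of them reached a measurable half-maximal inhibitory concentration within the range tested.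

The next compound, compound 4 `Cc1cnc(C(=O)OCCCOC(=O)CCCCC2CCSS2)c[n+]1[O-]`, differs from compound 3 in one place: a group of 8 heavy atoms (5 carbon, 2 nitrogen, 1 oxygen; one six-membered aromatic ring with 2 hetero atoms) in place of a group of 6 heavy atoms (5 carbon, 1 nitrogen; one six-membered aromatic ring with 1 hetero atom), on a carbonyl carbon. The shared chain and the ring bearing the two sulfur atoms are untouched.

For the measured compounds named here, no step between measured compounds is available to guide the expectation. Given that every value so far sits at the limit, as stated by the limit of > 800000 nM in this assay, at which 3 of the 3 values shown sit, the working expectation in this assay is no step beyond the scatter, with compound 4 also returning a limit rather than a number. The estimated step from compound 3 to compound 4 is a step that the limit leaves unreadable from compound 3 to compound 4. For compound 4 the expected value in this assay is 1000000 nM, with a range from 300000 nM to 3000000 nM.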

Compound 4, half-maximal inhibitory concentration: > 800000 nM
Compound 4: no number, only a limit; the forecaster's own chance of this, stated with the estimate: 85%; the middle value does not contradict the limit.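

In this assay compound 4 gives > 800000 nM as a limit of the assay and not a number. For the compounds shown here, no step from compound 3 to compound 4 can be read: the limit of > 800000 nM in this assay, at which 4 of the 4 values shown sit. The compounds shown leave open whether any change in this series yields a measurable half-maximal inhibitory concentration.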